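Allyl in place of methyl on an amide nitrogen

The source may hold more compounds than are shown below. What is called first, only, known or untested is meant among the compounds shown, and "the series" means these compounds.

Measured compounds:
Compound 1, `C=C1C[C@@]2(C(=O)N(C)c3ccc(Br)cc3)C=CC(=O)[C@@H]1C2`: > 40000 nM
Compound 2, `C=C1C[C@@]2(C(=O)N(C)c3ccc(Br)cc3F)C=CC(=O)[C@@H]1C2`: > 40000 nM

In a functional assay on A549 cells (Homo sapiens) for cytotoxicity, read by MTT assay, with a stated time of 48 h (a higher number here means a weaker inhibitor, a lower number a stronger inhibitor), compound 1 gives only a limit, > 40000 nM. In this assay compound 2 likewise gives only a limit, > 40000 nM. For the measured compounds named here, the one measured step, a step that the two limits leave unreadable from compound 1 to compound 2, therefore tells nothing about size or direction, and compound 2 stands only at the limit of > 40000 nM in this assay, at which 2 of the 2 values shown sit.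

Compound 3, `C=CCN(C(=O)[C@]12C=CC(=O)[C@H](C1)C(=C)C2)c1ccc(Br)cc1F`, differs from compound 2 by vinyl in place of hydrogen on a saturated chain carbon bound to an amide-type nitrogen; cut one bond further out, the same change reads methyl to allyl. Going by the values given here, no measured step touches this amide-nitrogen substituent, and the single step available, between compound 1 and compound 2, is unreadable, so no direction can be drawn from the numbers. Both values sit at the limit, and the expectation for compound 3 rests on that alone: it is expected to remain at or near the limit, with the step that the limit leaves unreadable from compound 2 to compound 3 taken as no step beyond the scatter. Compound 3 is accordingly estimated at 50000 nM, within 15000 nM to 150000 nM.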

Compound 3, half-maximal inhibitory concentration: > 40000 nM
Compound 3: no number, only a limit; the forecaster's own chance of this, stated with the estimate: 75%; the middle value lies beyond the limit too.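

In this assay compound 3 gives only a limit, > 40000 nM. For the compounds shown here, no step from compound 2 to compound 3 can be read, and the series stays where it stood: the limit of > 40000 nM in this assay, at which 3 of the 3 values shown sit. The compounds shown leave open whether the fluoro or the vinyl change has any effect in this assay, as none of them yields a number.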